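Adding a Second Trifluoromethyl Group on Two Different Cores

The source may report more compounds than this note shows. Statements on the series, on what has been measured and on what is new or still open speak of the compounds shown alone.

Compound 1, `CN(C(=O)NC(=O)c1ccc(Cl)cc1Cl)c1nc(C(F)(F)F)c(C(=O)N/N=C/c2cccc(C(F)(F)F)c2)s1`, is tested in a functional assay on MCF7 cells (Homo sapiens) for inhibition, read by MTT assay, with a stated time of 72 h (a lower number here means a stronger inhibitor, a higher number a weaker inhibitor), and gives 10.7 ug/mL. Compound 2, `CN(C(=O)NC(=O)c1ccc(Cl)cc1Cl)c1nc(C(F)(F)F)c(C(=O)N/N=C/c2cc(C(F)(F)F)cc(C(F)(F)F)c2)s1`, carries one more trifluoromethyl group on the same ring. In this assay compound 2 gives > 100 ug/mL, which is a limit of the assay rather than a number; (the limit of > 100 ug/mL in this assay, at which 1 of the 3 values shown sits). The change is trifluoromethyl in place of hydrogen on an aromatic carbon. The step from compound 1 to compound 2 is therefore an at least 9.3-fold higher number from compound 1 to compound 2 (0.97 log units; beyond the scatter).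

Compound 3, `Cc1nc(N(C)C(=O)NC(=O)c2c(F)cccc2F)sc1C(=O)N/N=C/c1cccc(C(F)(F)F)c1`, is built on a different core; how the core of compound 3 differs from that of compound 1 is not broken down here. In this assay compound 3 gives 28.2 ug/mL, a higher number than compound 1 shows.

Compound 4, `Cc1nc(N(C)C(=O)NC(=O)c2c(F)cccc2F)sc1C(=O)N/N=C/c1cc(C(F)(F)F)cc(C(F)(F)F)c1`, has not yet been measured. It differs from compound 3 by trifluoromethyl in place of hydrogen on an aromatic carbon, and the place of the change is described in the same words as for the step from compound 1 to compound 2, so this is the same change on a different core. If that change behaves alike on the core of compound 3, the step from compound 3 to compound 4 is expected to be a 5.3-fold higher number from compound 3 to compound 4 (0.73 log units; beyond the scatter). Compound 4 is expected to give about 150 ug/mL, most likely between 40 ug/mL and 500 ug/mL, because compound 3 already gives 28.2 ug/mL and the earlier step was an at least 9.3-fold higher number from compound 1 to compound 2 (0.97 log units; beyond the scatter).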

Compound 4, half-maximal inhibitory concentration: 11.6 ug/mL
Beside the measured number, compound 4's estimate is 13-fold (1.11 log units) above it; the whole stated range lies above it.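

In this assay, trifluoromethyl in place of hydrogen on the aromatic carbon makes compound 4 the stronger inhibitor of its pair, with a 2.4-fold lower number from compound 3 to compound 4 (0.39 log units; beyond the scatter). Among these compounds, the same change therefore does not carry over from one core to the other, since the two steps run in opposite directions and differ by more than the usual scatter of such measurements: the same change on two cores in this assay, an at least 9.3-fold higher number (0.97 log units; beyond the scatter) from compound 1 to compound 2 and a 2.4-fold lower number (0.39 log units; beyond the scatter) from compound 3 to compound 4, at least 22-fold (1.35 log units) apart, beyond the scatter of two such steps This shows that the result of this change on one core cannot be taken as a guide to its result on the other, but with only two matched pairs it gives no general rule, and it does not show which of the differences between the two cores turns the step around, or why.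

Compounds that alter just one part of the core at a time would be needed to find out which part decides the direction of the step. From the compounds shown here alone, it also remains open how other groups at the same place on the aromatic ring, such as an amine, a carboxylic acid or a longer chain, would behave on each of the two cores.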